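Cytotoxicity of the benzyl ether series: compound 3

The source may hold more compounds than are shown below. What is called first, only, known or untested is meant among the compounds shown, and "the series" means these compounds.

For the measured compounds named here, compound 2 `N#Cc1ccccc1COc1cc(O)c2c(=O)c(O)c(-c3ccccc3)oc2c1` stands as the only member with a number in an ADME assay on Huh-5-2 cells (Homo sapiens) for cytotoxicity, read by WST assay, with a stated time of 3 days; a higher number here means that more compound is tolerated, a lower number that less compound is tolerated: compound 2 gives 22000 nM. Compound 1 `O=c1c(O)c(-c2ccccc2)oc2cc(OCc3ccccc3Br)cc(O)c12` returns only a limit of the assay, > 100000 nM, in this assay. Going by the values given here, the one measured step, an at least 4.5-fold lower number from compound 1 to compound 2 (0.65 log units; beyond the scatter), is sized against that limit (the limit of > 100000 nM in this assay, at which 1 of the 2 values shown sits), so its true extent is open. Compound 3 `O=c1c(O)c(-c2ccccc2)oc2cc(OCc3cccc(Cl)c3)cc(O)c12` differs from compound 2 by 3-chlorophenyl in place of 2-cyanophenyl on a saturated chain carbon bound to an oxygen on an aromatic ring. Among the compounds with values here, only the step from compound 1 to compound 2 bears on this change, and it moved from a halogen to a nitrile; compound 3 moves back from a nitrile to a halogen, though chloro rather than bromo. Since an at least 4.5-fold lower number from compound 1 to compound 2 (0.65 log units; beyond the scatter) lowered the tolerated concentration at least modestly, a partial return toward the limit is expected for compound 3, as the step of a 2.3-fold higher number from compound 2 to compound 3 (0.36 log units; beyond the scatter). Compound 3 is estimated at 50000 nM in this assay, between 15000 nM and 150000 nM, with a fair chance that only a limit is reported.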

Compound 3, half-maximal cytotoxic concentration: > 100000 nM
Compound 3: a limit, no number (the forecaster's own chance of this, stated with the estimate: 40%); middle value at least 2.0-fold (0.30 log units) away from the limit.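

The step from 2-cyanophenyl to 3-chlorophenyl on a saturated chain carbon bound to an oxygen on an aromatic ring is an at least 4.5-fold higher number from compound 2 to compound 3 (0.65 log units; beyond the scatter), so compound 2 now stands apart from two halogen-bearing partners rather than one. The step between compound 1 and compound 3 cannot be read, and 2-bromophenyl and 3-chlorophenyl cannot be ordered in this assay. Among the three compounds, only the nitrile-bearing compound 2 gives a number, while both halogen-bearing compounds stop at a limit: the limit of > 100000 nM in this assay, at which 2 of the 3 values shown sit.

Compound 3 changes both the group and the name of its ring position, so the compounds shown do not tell whether the nitrile alone goes with the lower number. Also open, going by these compounds, are how far compound 1 and compound 3 lie past the limit and how 3-cyanophenyl, or a benzyl ring carrying an amine or a carboxylic acid, would read in this assay.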